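Naphthalen-2-yl in Place of Benzyl on a Sugar Acetal

The source may hold more compounds than are shown below. What is called first, only, known or untested is meant among the compounds shown, and "the series" means these compounds.

Three compounds share a fused bicyclic sugar-like core with a phenyl group and differ in the group that sits on the saturated ring carbon between the two ring oxygens. Compound 1 `C=CC[C@@H]1O[C@@H]2CO[C@@H](c3ccccc3)O[C@H]2[C@H](OC)[C@H]1OC` has a prop-2-enyl side chain and two methoxy groups, and in a functional assay on HEL cells (Homo sapiens) for cytotoxicity (a higher number here means that more compound is tolerated, a lower number that less compound is tolerated), compound 1 gives "not determined" (no result reported). Compound 2 `O[C@@H]1[C@@H](O)[C@H](c2ccccc2)O[C@@H]2CO[C@@H](c3ccc4ccccc4c3)O[C@@H]12` carries a naphthalen-2-yl group and two free hydroxyl groups. In this assay compound 2 reaches only a limit of the assay, >= 400 ug/mL, as the limit of >= 400 ug/mL in this assay, at which 1 of the 3 values shown sits, records. Compound 3 `CO[C@@H]1[C@@H](OC)[C@H](c2ccccc2)O[C@@H]2CO[C@@H](Cc3ccccc3)O[C@@H]12` bears a benzyl group and two methoxy groups; in this assay compound 3 gives "not determined" (no result reported), so no number places it among the others. Compound 4 `CO[C@@H]1[C@@H](OC)[C@H](c2ccccc2)O[C@@H]2CO[C@@H](c3ccc4ccccc4c3)O[C@@H]12` is the next step, (naphthalen-2-yl in place of benzyl on a saturated ring carbon). Among the measured compounds shown here, no measured step exists in this assay for this change, so the size of the step cannot be taken from data; on the single limit seen, no movement beyond the scatter is expected. Compound 4 is estimated to give 400 ug/mL in this assay, within 150 ug/mL to 400 ug/mL.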

Compound 4, minimum cytotoxic concentration: >= 16 ug/mL
Compound 4: a limit, no number; the forecaster's own chance of this, stated with the estimate: 70%; the middle value does not contradict the limit.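

In this assay compound 4 gives >= 16 ug/mL as a limit and not a number. With no single number for compound 3 either, no step can be read between compound 3 and compound 4. What naphthalen-2-yl in place of benzyl does in this assay stays open for the compounds shown.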